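Branching the side chain: a tert-butyl analogue awaits testing

The source may hold more compounds than are shown below. What is called first, only, known or untested is meant among the compounds shown, and "the series" means these compounds.

Compound 1, `CC(C)/N=C(\NC#N)Nc1cccnc1`: 2.5 mg/kg
Compound 2, `CCCC(C)(C)/N=C(\NC#N)Nc1cccnc1`: 1 mg/kg
Compound 3, `CC(C)CC(C)(C)/N=C(\NC#N)Nc1cccnc1`: 2.5 mg/kg

All three compounds share one core and were measured in a functional assay on the whole organism (blood, strain Wistar-Okamoto) with Rattus norvegicus as the target, with a stated time of 5 days; on this read-out lower numbers stand for an effect already at smaller amounts and higher numbers for an effect only at larger amounts of compound. Compound 3 stands level with compound 1, and together they give the highest numbers of the three; compound 2 gives the lowest, as seen in a 2.5-fold higher number from compound 2 to compound 3 (0.40 log units; beyond the scatter). Compound 4, `CC(C)(C)C(C)(C)/N=C(\NC#N)Nc1cccnc1`, has not yet been measured. It differs from compound 3 by tert-butyl in place of isobutyl on a saturated chain carbon bound to a double-bonded nitrogen and two saturated chain carbons. Within the data shown here, three measured steps bear on this change. a 2.5-fold lower number from compound 1 to compound 2 (0.40 log units; beyond the scatter) and no change at the digits printed from compound 1 to compound 3 (within the scatter) show that lengthening the chain at this carbon had at most a modest effect, while a 2.5-fold higher number from compound 2 to compound 3 (0.40 log units; beyond the scatter) shows a modest rise in the number when the chain grew by one methyl. Rearranging the same four carbons into a tert-butyl is therefore expected to move this assay little, with no clear direction. For compound 4 the expected step is no change at the digits printed from compound 3 to compound 4 (within the scatter). Compound 4 is expected to give 2.5 mg/kg, within a range of 1 mg/kg to 5 mg/kg.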

Compound 4, minimum effective dose: 50 mg/kg
Beside the measured number, compound 4's estimate is 20-fold (1.30 log units) below it; measured number above the stated range.
By their numbers in this assay, from the lowest: compound 2; then compounds 1 and 3 (each within the scatter of the next); then compound 4.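

In this assay, among these compounds, the chain on this saturated carbon had so far shifted the number only modestly, but tert-butyl in place of isobutyl, with the same atoms joined differently, gives a large rise (a 20-fold higher number from compound 3 to compound 4 (1.30 log units; beyond the scatter)), and tert-butyl is just as far out against propyl (a 50-fold higher number from compound 2 to compound 4 (1.70 log units; beyond the scatter)) and hydrogen (a 20-fold higher number from compound 1 to compound 4 (1.30 log units; beyond the scatter)). This place therefore responds to how the carbons of the group are arranged and not merely to their count, and compound 4 stands alone at the high end of the series. Nothing given here explains this jump.

The compounds shown leave open whether the rise belongs to tert-butyl alone or would also appear with a smaller branched group such as isopropyl. Going by these compounds, how a cyclopentyl ring or an amine on the chain would fare at this place also remains open.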